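The source may hold more compounds than are shown below. What is called first, only, known or untested is meant among the compounds shown, and "the series" means these compounds.

In a functional assay on KG-1a cells (Homo sapiens) for inhibition, with a stated time of 24 h (a lower number here means a stronger inhibitor, a higher number a weaker inhibitor), three compounds sharing one core have been measured: compound 1 `O=[N+]([O-])c1cccc(Nc2nnc(-c3c[nH]c4ccccc34)o2)c1` gives 25500 nM, compound 2 `Clc1cccc(Nc2nnc(-c3c[nH]c4ccccc34)o2)c1` gives 32700 nM, and compound 3 `Clc1ccc(Nc2nnc(-c3c[nH]c4ccccc34)o2)cc1Cl` gives 45300 nM. Compound 2 stands among these numbers with no clear gap to either neighbour.

Compound 4 `c1ccc(CNc2nnc(-c3c[nH]c4ccccc34)o2)cc1` has benzyl in place of 3-chlorophenyl on a nitrogen on an aromatic ring. Among the measured compounds shown here, two measured steps bear on this change, though only indirectly. Chloro in place of nitro on an aromatic carbon gave a 1.3-fold higher number from compound 1 to compound 2 (0.11 log units; within the scatter), and chloro in place of hydrogen on an aromatic carbon gave a 1.4-fold higher number from compound 2 to compound 3 (0.14 log units; within the scatter). For the measured compounds named here, both of these changes were made on an aromatic carbon, whereas the new change is on the nitrogen, and no step of that kind has been measured. Going by the values given here, the two small steps are therefore the only guide, and they point to no particular direction. No shift beyond the scatter is expected in this assay, although the range must stay wide to allow for the untested change. The expected step is a 1.1-fold higher number from compound 2 to compound 4 (0.03 log units; within the scatter). For compound 4, the estimated value is 35000 nM, with an expected range from 15000 nM to 80000 nM.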

Compound 4, half-maximal inhibitory concentration: > 100000 nM
Compound 4 was reported as a limit; the forecaster's own chance of this, stated with the estimate: 15%; middle value at least 2.8-fold (0.45 log units) away from the limit.
By their numbers in this assay, from the lowest: compounds 1, 2 and 3 (each within the scatter of the next). At a limit, above all of these: compound 4.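

In this assay, the steps among compounds 1, 2 and 3 changed only groups on an aromatic carbon and stayed within the scatter, so they gave no sign that this part of the molecule mattered. Among the compounds shown here, the change on the nitrogen is the first to move beyond the scatter: benzyl in place of 3-chlorophenyl gives an at least 3.0-fold higher number from compound 2 to compound 4 (0.48 log units; beyond the scatter). The two groups have the same count of heavy atoms and each carries one six-membered aromatic ring of carbon only, yet the full size of the step stays unknown because the reading for compound 4 is a limit: the limit of > 100000 nM in this assay, at which 1 of the 4 values shown sits.

The swap removes the chlorine and also changes how the ring is joined to the nitrogen, so the compounds shown cannot say which of these two differences matters. A plain phenyl on that nitrogen, a benzyl carrying a chloro group and a longer chain such as 2-phenylethyl would each help to separate the two and show how far the ring can sit from the nitrogen in this assay.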